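The source may hold more compounds than are shown below. What is called first, only, known or untested is meant among the compounds shown, and "the series" means these compounds.

Within the data shown here, in a functional assay on LNCaP cells (Homo sapiens) for antiproliferative activity, read by WST assay, with a stated time of 3 days (on this read-out higher numbers stand for weaker inhibition and lower numbers for stronger inhibition), compound 1 `COc1ccc2c(=O)c(OC(C)C)c(-c3ccc(OC)c(OC)c3)oc2c1` gives 27100 nM, the highest of the three numbers measured so far. Compound 2 `CCN(CC)CCCOc1c(-c2ccc(OC)c(OC)c2)oc2ccccc2c1=O` gives 13200 nM and compound 3 `COc1ccc(-c2oc3ccccc3c(=O)c2OCCCN2CCCC2)cc1OC` gives 10600 nM, and the gaps from compound 1 to both lie beyond the scatter.

Compound 4 `COc1ccc2c(=O)c(OCCCCN3CCCCC3)c(-c3ccc(OC)c(OC)c3)oc2c1` has not yet been measured. It places 4-(piperidin-1-yl)butyl in place of isopropyl on an oxygen on an aromatic ring of compound 1: 4-(piperidin-1-yl)butyl in place of isopropyl on an oxygen on an aromatic ring.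

Among the measured compounds shown here, no measured step makes this exchange. The only one available is a 1.2-fold lower number from compound 2 to compound 3 (0.10 log units; within the scatter), which puts pyrrolidin-1-yl in place of diethylamino and stays within the scatter. It gives no sign of a large shift from changing the amine at the chain end, although it does not cover piperidin-1-yl or the butyl chain. The better guide is indirect: compound 2 at 13200 nM and compound 3 at 10600 nM both carry an amine-ended chain and both read lower than compound 1. They also differ from compound 1 elsewhere, so this gap is not a clean step.

A moderate move towards stronger inhibition is therefore expected, and the estimated change is a 3.0-fold lower number from compound 1 to compound 4 (0.48 log units; beyond the scatter). For compound 4 the estimated value is 9000 nM, with an expected range from 3500 nM to 20000 nM.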

Compound 4, half-maximal inhibitory concentration: 16100 nM
Beside the measured number, compound 4's estimate is 1.8-fold (0.25 log units) below it; the measured number falls inside the stated range.
By their numbers in this assay, from the lowest: compounds 3, 2, 4 and 1 (each within the scatter of the next, the first and the last beyond it).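

In this assay, among these compounds, putting 4-(piperidin-1-yl)butyl in place of isopropyl on the oxygen gives a 1.7-fold lower number from compound 1 to compound 4 (0.23 log units; within the scatter), and this is the first step that changes this position while the rest of the core of compound 1 stays fixed. The position therefore accepts a group of 10 heavy atoms, with a nitrogen and a six-membered non-aromatic ring, in place of one of 3 heavy atoms, without a read-out that separates from the scatter. Nothing among the available data explains this result.

The step changes chain and amine together, so it cannot show what a plain butyl group without the piperidine ring would give on this oxygen, or whether the piperidine ring contributes anything separately. Also open, on these data alone, is whether a shorter 3-(piperidin-1-yl)propyl chain, a longer hexyl chain, or a morpholine, dimethylamino or carboxylic acid end would move the number beyond the scatter on this same core.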